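Chloro to Cyano Swap Across Two Sulfonamide Benzanilide Cores

A few compounds are considered here, and "the series" means these few. Any claim that something is new, unique, unknown or untested is made for them only; others in the source may bear on it.

Measured compounds:
compound 1, `CCS(=O)(=O)Nc1ccc(NC(=O)c2ccc(Cl)cc2)cc1OC`, 60100 nM
compound 2, `CCS(=O)(=O)Nc1ccc(NC(=O)c2ccc(C#N)cc2)cc1OC`, 66400 nM
compound 3, `CS(=O)(=O)Nc1ccc(NC(=O)c2ccc(Cl)cc2)cc1Cl`, 79900 nM

In an ADME assay on RAW264.7 cells (Mus musculus) for cytotoxicity, read by MTT assay, with a stated time of 48 h (a higher number here means a weaker inhibitor, a lower number a stronger inhibitor), compound 1 gives 60100 nM. Compound 2 differs from compound 1 by cyano in place of chloro on an aromatic carbon and in this assay compound 2 gives 66400 nM, so that a 1.1-fold higher number from compound 1 to compound 2 (0.04 log units; within the scatter). Compound 3 gives 79900 nM in this assay; its value sits within the scatter of both compound 1 and compound 2, so no order among the three is claimed. The difference between the core of compound 3 and the core of compound 1 is not broken down here.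

Compound 4, `CS(=O)(=O)Nc1ccc(NC(=O)c2ccc(C#N)cc2)cc1Cl`, has not yet been measured. It differs from compound 3 by cyano in place of chloro on an aromatic carbon. This is the same change that separates compound 2 from compound 1, made on the other core, and the two changes occur at the same kind of place. The step from compound 3 to compound 4 is therefore expected to be small, as the earlier step of a 1.1-fold higher number from compound 1 to compound 2 (0.04 log units; within the scatter) was, and the estimate rests on that earlier step together with the value of compound 3. Compound 4 is expected to give about 88000 nM in this assay, with a likely range from 50000 nM to 150000 nM, which corresponds to an expected step of a 1.1-fold higher number from compound 3 to compound 4 (0.04 log units; within the scatter).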

Compound 4, half-maximal inhibitory concentration: > 250000 nM
Compound 4 ended at the assay's limit; the forecaster's own chance of this, stated with the estimate: 15%; middle value at least 2.8-fold (0.45 log units) away from the limit.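

In this assay, cyano in place of chloro on an aromatic carbon gave an at least 3.1-fold higher number from compound 3 to compound 4 (0.49 log units; beyond the scatter), and this step differs from the one seen for the same change on the other core: the same change on two cores in this assay, a 1.1-fold higher number (0.04 log units; within the scatter) from compound 1 to compound 2 and an at least 3.1-fold higher number (0.49 log units; beyond the scatter) from compound 3 to compound 4, at least 2.8-fold (0.45 log units) apart, beyond the scatter of two such steps

The reading for compound 4 is a limit of the assay and not a number, so only a lower bound on the size of this step can be read: the limit of > 250000 nM in this assay, at which 1 of the 4 values shown sits.

Within these two pairs, the size of the step from this change did not carry over from one core to the other, but the pairs do not show which feature of the cores goes with the difference, and two pairs establish no rule for the wider series.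

The compounds shown leave open whether the ethyl or methyl chain on the sulfonyl group, or the methoxy or chloro group on the ring, goes with the difference between the two steps, since these cores differ in both places at once. They also leave open how another group in place of the chloro, such as trifluoromethyl or a carboxylic acid, would behave on either core.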